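A few compounds are considered here, and "the series" means these few. Any claim that something is new, unique, unknown or untested is made for them only; others in the source may bear on it.

Compound 1 `COc1cc(OC)c(OC)cc1/C=C/COC(=O)/C=C/c1ccc(OC)c(OC)c1`: 173 mg/kg
Compound 2 `COc1cc(OC)c(OC)cc1/C=C/COC(=O)/C=C/c1ccc(Br)cc1`: 193 mg/kg

In a functional assay on the whole organism (strain Kunming) with Mus musculus as the target, with a stated time of 0.5 h (on this read-out lower numbers stand for an effect already at smaller amounts and higher numbers for an effect only at larger amounts of compound), compound 2 gives 193 mg/kg, level with compound 1 within the scatter. Compound 3 `COc1cc(OC)c(OC)cc1/C=C/COC(=O)/C=C/c1ccccc1C(F)(F)F` carries 2-(trifluoromethyl)phenyl in place of 4-bromophenyl on a double-bonded chain carbon bound to a double-bonded chain carbon. Among the compounds with values here, one measured step bears on this, a 1.1-fold higher number from compound 1 to compound 2 (0.05 log units; within the scatter), a swap of groups at the same place. That single step is small, so no change beyond the scatter is expected in this assay. The expected step is a 1.0-fold lower number from compound 2 to compound 3 (0.02 log units; within the scatter). For compound 3 the estimate is 185 mg/kg, with an expected range of 95 mg/kg to 360 mg/kg.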

Compound 3, dose for half-maximal effect: > 200 mg/kg
Compound 3 gave a limit, no number; the forecaster's own chance of this, stated with the estimate: 5%; at least 1.0-fold (0.03 log units) between middle value and limit.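

In this assay compound 3 gives a limit and not a number, so 2-(trifluoromethyl)phenyl at this place has no measured size of effect: the limit of > 200 mg/kg in this assay, at which 1 of the 3 values shown sits. The result gives an at least 1.0-fold higher number from compound 2 to compound 3 (0.01 log units; that floor lies within the scatter) and an at least 1.1-fold higher number from compound 1 to compound 3 (0.06 log units; that floor lies within the scatter) and so shows no change beyond the scatter at this place. Unlike the earlier compounds, it sets only a floor, and how far compound 3 lies past its limit remains unknown. Also open, from the compounds shown here alone, is whether any other group on a double-bonded chain carbon, such as an amine or a carboxylic acid on the phenyl ring, would move the number beyond the scatter.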